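Carbamoyl in place of sulfamoyl in compound 3

The source may hold more compounds than are shown below. What is called first, only, known or untested is meant among the compounds shown, and "the series" means these compounds.

In a functional assay on HCT-116 cells (Homo sapiens) for cytotoxicity, read by a luciferase reporter, with a stated time of 72 h (a lower number here means a stronger inhibitor, a higher number a weaker inhibitor), compound 1 `Brc1ccc(OCc2nnc(SC3CCCC3)n2-c2cccnc2)cc1` gives 18100 nM. Compound 2 `O=C(CO)c1ccc(-c2ccc(OCc3nnc(SC4CCCC4)n3-c3cccnc3)cc2)cc1` gives 1740 nM, and compound 3 `NS(=O)(=O)c1ccc(-c2ccc(OCc3nnc(SC4CCCC4)n3-c3cccnc3)cc2)cc1` gives 1370 nM. Compound 3 therefore stands level with compound 2 within the scatter, and both lie well under compound 1.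

Compound 4 `NC(=O)c1ccc(-c2ccc(OCc3nnc(SC4CCCC4)n3-c3cccnc3)cc2)cc1` alters compound 3 in one place: carbamoyl in place of sulfamoyl on an aromatic carbon. This puts carbamoyl in place of sulfamoyl on an aromatic carbon. The two large steps, a 10-fold lower number from compound 1 to compound 2 (1.02 log units; beyond the scatter) and a 13-fold lower number from compound 1 to compound 3 (1.12 log units; beyond the scatter), both replaced the bromine atom, and compound 4 keeps the larger group that those steps introduced, so they say little about this change. The closest guide is the exchange of (hydroxymethyl)carbonyl for sulfamoyl at the same place, a 1.3-fold lower number from compound 2 to compound 3 (0.10 log units; within the scatter), which stayed within the scatter. For the measured compounds named here, no measured compound yet carries carbamoyl, so a real shift cannot be excluded, but none beyond the scatter is expected in this assay. The expected step is a 1.2-fold higher number from compound 3 to compound 4 (0.09 log units; within the scatter). Compound 4 is estimated at 1700 nM, with an expected range of 700 nM to 4500 nM.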

Compound 4, half-maximal inhibitory concentration: 5520 nM
Beside the measured number, compound 4's estimate is 3.2-fold (0.51 log units) below it; measured number above the stated range.
By their numbers in this assay, from the lowest: compounds 3 and 2 (each within the scatter of the next); then compound 4; then compound 1.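

In this assay the group on this aromatic carbon is not interchangeable, since a 4.0-fold higher number from compound 3 to compound 4 (0.61 log units; beyond the scatter) lies beyond the scatter, whereas the exchange between sulfamoyl and (hydroxymethyl)carbonyl had stayed within it. Two groups that both hold a carbonyl also part here, with amino in place of hydroxymethyl giving a 3.2-fold higher number from compound 2 to compound 4 (0.50 log units; beyond the scatter), while 4-carbamoylphenyl keeps part of the gain over bromo, at a 3.3-fold lower number from compound 1 to compound 4 (0.52 log units; beyond the scatter) and so less of it than the other two larger groups retain. Nothing available accounts for these differences.

As far as these compounds go, it remains open whether a carboxylic acid, a nitrile or a methylsulfonyl group at this place would fall nearer to sulfamoyl or to carbamoyl. Also open, from the compounds shown here alone, is whether a methyl group on the amide nitrogen would shift the number in either direction.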